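The source may hold more compounds than are shown below. What is called first, only, known or untested is meant among the compounds shown, and "the series" means these compounds.

Measured compounds:
compound 1 `C=CCn1ncc2c(C)nc(C(C)C)n2c1=O` gives > 48000 nM in a functional assay for inhibition, with Homo sapiens as the target (on this read-out lower numbers stand for stronger inhibition and higher numbers for weaker inhibition), a limit of the assay rather than a number.
Compound 2 `CCCc1nc(C)c2c(-c3ccccc3)nnc(SC)n12` gives > 48000 nM in this assay, also a limit and not a number.
Compound 3 `C=CCn1ncc2c(C)nc(CCC)n2c1=O` gives 40000 nM in this assay.

Compound 3 and compound 1 share a core and differ in one place: isopropyl in place of propyl on an aromatic carbon. The measured step is an at least 1.2-fold higher number from compound 3 to compound 1 (0.07 log units; that floor lies within the scatter). Its floor lies within the scatter, so no direction can be read from it. Going by the values given here, the limit is the only thing the pair shows, because of the limit of > 48000 nM in this assay, at which 2 of the 3 values shown sit.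

Compound 2 carries a different core; the difference between the two cores of compound 2 and compound 3 is not broken down here. Compound 4 `CSc1nnc(-c2ccccc2)c2c(C)nc(C(C)C)n12` is not yet measured in this assay. It differs from compound 2 as isopropyl in place of propyl on an aromatic carbon. Among the compounds with values here, the place lines of the two changes agree word for word, so this is the same change as the one from compound 3 to compound 1.

On that measured pair the change gave at most a small step whose floor is within the scatter, and compound 2 already sits at the limit of the assay. The step from compound 2 to compound 4 is therefore expected to be about a step that the limit leaves unreadable from compound 2 to compound 4, i.e. no real movement. Compound 4 is estimated at 60000 nM, with a range from 30000 nM to 150000 nM, and the assay is most likely to return only a limit again.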

Compound 4, half-maximal inhibitory concentration: > 48000 nM
Compound 4 ended at the assay's limit; the forecaster's own chance of this, stated with the estimate: 85%; the middle value does not contradict the limit.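

Compound 4 gives > 48000 nM in this assay, a limit and not a number. The step between compound 2 and compound 4 therefore cannot be read, because of where both values sit: the limit of > 48000 nM in this assay, at which 3 of the 4 values shown sit.

Still open is whether isopropyl in place of propyl on an aromatic carbon changes inhibition at all on either core; of the compounds shown, only compound 3 carries a number.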